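This account rests on a few compounds, and the source may have more. Where it says the series, first, only, none or still open, it means among the compounds named here.

Of the compounds shown here, three sharing one core have been measured in a physicochemical assay for lipophilicity, measured as octanol-water partition, at pH 7.4; a lower number here means a more polar compound, a higher number a more lipophilic compound. Compound 1 `FC(F)(F)c1ccc(NC2=NCCC3(CCCCC3)S2)cc1` gives 2.18. Compound 2 `Brc1ccc(NC2=NCCC3(CCCCC3)S2)cc1` gives 2.53. Compound 3 `CCc1ccc(NC2=NCCC3(CCCCC3)S2)cc1` gives 2.31, the second highest of the three numbers; its gap to compound 1 lies within the scatter, as does a number 0.22 log units lower from compound 2 to compound 3 (within the scatter). Going by the values given here, the only step beyond the scatter among them is a number 0.35 log units higher from compound 1 to compound 2 (beyond the scatter). Compound 4 `COc1ccc(NC2=NCCC3(CCCCC3)S2)cc1` has not yet been measured in this assay. methoxy in place of ethyl on an aromatic carbon The measured steps each exchange a group on the same aromatic carbon, but none of them brings in a hydrogen-bond acceptor, so none of them matches this change closely; the nearest, a number 0.22 log units lower from compound 2 to compound 3 (within the scatter) and a number 0.13 log units higher from compound 1 to compound 3 (within the scatter), were both small. With the methoxy group and its hydrogen-bond acceptor entering, a downward step in this assay is expected, estimated as a number 0.56 log units lower from compound 3 to compound 4 (beyond the scatter), larger than the steps seen so far. Compound 4 is accordingly expected to give about 1.75, in a range from 1.35 to 2.15.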

Compound 4, distribution coefficient: 0.8
For compound 4 the middle estimate is 0.95 log units above the measured one; measured number below the stated range.
By their numbers in this assay, from the lowest: compound 4; then compounds 1, 3 and 2 (each within the scatter of the next, the first and the last beyond it).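

Among the groups at this place on the aromatic ring, para to a large group, trifluoromethyl, bromo and ethyl had differed by modest steps at most in this assay but methoxy brings a number 1.51 log units lower from compound 3 to compound 4 (beyond the scatter) and also a number 1.73 log units lower from compound 2 to compound 4 (beyond the scatter) and a number 1.38 log units lower from compound 1 to compound 4 (beyond the scatter) and so sets compound 4 apart from all three. The position therefore does respond strongly to the group it carries, and the exchange of ethyl for methoxy does so with 2 heavy atoms on each side, the entering group adding 1 hydrogen-bond acceptor. Nothing available accounts for the size of this drop.

As far as these compounds go, whether the drop is peculiar to methoxy remains open, since ethoxy, hydroxyl or dimethylamino at this place could separate the role of the oxygen from that of the attached methyl. Whether a similar step would appear with methoxy elsewhere on the aromatic ring also stays unanswered.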